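Methyl on the pyrimidinone ring of the bis(ethylthio) nucleoside

This account rests on a few compounds, and the source may have more. Where it says the series, first, only, none or still open, it means among the compounds named here.

Measured so far:
compound 1 `CCS[C@@H]1[C@H](SCC)[C@@H](Cn2cc(-c3ccc(OC)cc3)nn2)O[C@H]1n1ccc(=O)[nH]c1=O` — 16200 nM
compound 2 `CCOC(=O)c1cn(C[C@H]2O[C@@H](n3ccc(=O)[nH]c3=O)[C@H](SCC)[C@@H]2SCC)nn1` — >= 100000 nM

Within the data shown here, in a functional assay on HepG2 cells (Homo sapiens) for cytotoxicity, read by MTT assay, with a stated time of 72 h (a higher number here means that more compound is needed for the effect, a lower number that less compound is needed), compound 1 gives 16200 nM, the only number obtained. Compound 2 returns >= 100000 nM, which is a limit of the assay and not a number. Compound 2 thus sits at the limit of >= 100000 nM in this assay, at which 1 of the 2 values shown sits. Among the measured compounds shown here, the one measured step, an at least 6.1-fold higher number from compound 1 to compound 2 (0.79 log units; beyond the scatter), concerns the aryl substituent on the triazole and reads as a weakening of the effect.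

Compound 3 `CCS[C@@H]1[C@H](SCC)[C@@H](Cn2cc(-c3ccc(OC)cc3)nn2)O[C@H]1n1cc(C)c(=O)[nH]c1=O` keeps everything of compound 1 and differs only by methyl in place of hydrogen on an aromatic carbon. For the measured compounds named here, no measured step touches this position, so the step from compound 1 to compound 2 offers no direct guide. With nothing to set against it, compound 3 is expected to show a step of a 1.0-fold lower number from compound 1 to compound 3 (0.01 log units; within the scatter), that is, none beyond the scatter. Compound 3 is therefore estimated at 16000 nM, with a range from 6000 nM to 45000 nM.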

Compound 3, half-maximal effective concentration: 22800 nM
Compound 3: middle estimate off by 1.4-fold (0.15 log units), on the low side, and the stated range covers the measured number.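

In this assay, methyl in place of hydrogen on the aromatic carbon of the six-membered aromatic ring with 2 nitrogen gives a 1.4-fold higher number from compound 1 to compound 3 (0.15 log units; within the scatter) and so does not separate the two compounds. Among these compounds, this is the first reading at this position, since the one earlier step, an at least 6.1-fold higher number from compound 1 to compound 2 (0.79 log units; beyond the scatter) for the ethoxycarbonyl swap, concerns a different place in the molecule. No measured property shown here bears on this methyl result.

Still open, on these data alone, is whether an ethyl chain, a bromine atom or an amine on this same carbon would stay as close to compound 1 as methyl does. Also open, as far as these compounds go, is whether methyl here would register at all with the ethoxycarbonyl group of compound 2, since >= 100000 nM for that compound is a limit of the assay and not a number.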